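Heptyl in place of cyclohexyl on the core

The source may hold more compounds than are shown below. What is called first, only, known or untested is meant among the compounds shown, and "the series" means these compounds.

Compound 1 `Nc1ncnc2c1c(-c1cc(C3CC3)on1)nn2C1CCCCC1`: 290 nM
Compound 2 `CC(C)n1nc(-c2cc(-c3ccc(F)cc3)on2)c2c(N)ncnc21`: > 10000 nM, a limit of the assay
Compound 3 `CC(C)c1cc(-c2nn(C(C)C)c3ncnc(N)c23)no1`: 5130 nM

Of the compounds shown here, three built on the shared core have been measured in an assay on TT cells for inhibition of proto-oncogene tyrosine-protein kinase receptor Ret variant C634W (Homo sapiens), read by MTT assay, with a stated time of 10 days; a higher number here means a weaker inhibitor of growth, a lower number a stronger inhibitor of growth. Compound 1 gives 290 nM, the lowest of the two numbers recorded; its nearest neighbour is compound 3, which lies beyond the scatter from it. Compound 2 reaches only a limit of the assay, > 10000 nM, and that stands as the limit of > 10000 nM in this assay, at which 1 of the 3 values shown sits. Among the measured compounds shown here, the one measured step between close pairs is an at least 1.9-fold lower number from compound 2 to compound 3 (0.28 log units; that floor lies within the scatter), and it concerns the group on the aromatic carbon of the 1,2-oxazole rather than the group on the aromatic nitrogen.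

Compound 4 `CCCCCCCn1nc(-c2cc(C3CC3)on2)c2c(N)ncnc21` is not yet measured. It differs from compound 1 in one place: heptyl in place of cyclohexyl on an aromatic nitrogen. For the measured compounds named here, no measured step touches that position, so nothing in the data shows how a change there moves this assay. A flexible chain in place of a ring is, on the evidence here, an untested move, and a modest loss is expected as the more likely outcome, with a gain not excluded. Compound 4 is expected to give 800 nM, between 200 nM and 4000 nM, which would be a step of a 2.8-fold higher number from compound 1 to compound 4 (0.44 log units; beyond the scatter).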

Compound 4, concentration for 50% growth inhibition: > 10000 nM
Compound 4 was reported as a limit; the forecaster's own chance of this, stated with the estimate: 10%; at least 12-fold (1.09 log units) between middle value and limit.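

Among the compounds shown here, the aromatic nitrogen, which no earlier step touched, proves to be a sensitive position in this assay: heptyl in place of cyclohexyl gives an at least 34-fold higher number from compound 1 to compound 4 (1.53 log units; beyond the scatter). The 5-cyclopropyl-1,2-oxazol-3-yl group is the same in both compounds, so this large step belongs to the change on the nitrogen alone, and on this core the open heptyl chain does not stand in for the cyclohexyl ring. Compound 4 stands at a limit of the assay, so the step is a floor and its full size cannot be read: the limit of > 10000 nM in this assay, at which 2 of the 4 values shown sit.

With one ring and one chain compared at this position, the compounds shown do not separate the loss of the ring from the length of the chain, and a shorter chain such as butyl or a smaller ring such as cyclopentyl on the same nitrogen would bear on that. Going by these compounds, compound 3 carries isopropyl on the nitrogen but also a different group on the 1,2-oxazole, so the effect of a small branched group at this position with the cyclopropyl group in place remains open.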